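Swapping Chloro for Methyl on the Sulfonyl Aryl Ring

The source may hold more compounds than are shown below. What is called first, only, known or untested is meant among the compounds shown, and "the series" means these compounds.

Of the compounds shown here, three sharing one core have been tested in a functional assay on A-375 cells (Homo sapiens) for cytotoxicity, read by MTT assay; on this read-out lower numbers stand for stronger inhibition and higher numbers for weaker inhibition. Compound 1 `O=S(=O)(NCCCNc1nccc(-c2c(-c3cccc(F)c3)nc3sccn23)n1)c1ccc(Br)cc1` gives 7040 nM. Compound 2 `O=S(=O)(NCCCNc1nccc(-c2c(-c3cccc(F)c3)nc3sccn23)n1)c1ccc(F)cc1` gives 14500 nM. Compound 3 `O=S(=O)(NCCNc1nccc(-c2c(-c3cccc(F)c3)nc3sccn23)n1)c1ccc(Cl)cc1` gives 18600 nM, the highest of the three numbers; its gap to compound 2 lies within the scatter, while a 2.6-fold higher number from compound 1 to compound 3 (0.42 log units; beyond the scatter) lies beyond it. Among the compounds with values here, the only change among the measured compounds confined to the six-membered aromatic ring of carbon only is a 2.1-fold higher number from compound 1 to compound 2 (0.31 log units; beyond the scatter), a modest shift. Compound 4 `Cc1ccc(S(=O)(=O)NCCNc2nccc(-c3c(-c4cccc(F)c4)nc4sccn34)n2)cc1` differs from compound 3 by methyl in place of chloro on an aromatic carbon. Within the data shown here, no measured step tries a methyl at that place, and the halogen swap on that ring gave only a modest step, so a small step at most is expected in this assay, most likely toward a somewhat higher number. The expected change is a 1.2-fold higher number from compound 3 to compound 4 (0.07 log units; within the scatter). Compound 4 is therefore estimated at 22000 nM, with a range from 9000 nM to 55000 nM.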

Compound 4, half-maximal inhibitory concentration: 15400 nM
Compound 4: middle estimate off by 1.4-fold (0.15 log units), on the high side; measured number inside the range.
By their numbers in this assay, from the lowest: compound 1; then compounds 2, 4 and 3 (each within the scatter of the next).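

In this assay, methyl on this aromatic carbon, para to a large group, reads the same as chloro, with a 1.2-fold lower number from compound 3 to compound 4 (0.08 log units; within the scatter), so this swap of one heavy atom for another gives no change that can be told from the scatter. Compound 4 also stays level with compound 2, with a 1.1-fold higher number from compound 2 to compound 4 (0.03 log units; within the scatter), whereas a 2.2-fold higher number from compound 1 to compound 4 (0.34 log units; beyond the scatter) keeps compound 1 apart, now from all three other compounds. Nothing available here offers an explanation for these numbers.

From the compounds shown here alone, whether an amine or a carboxylic acid at this ring position would move the number beyond the scatter remains open. The compounds shown also leave open how much of the gap around compound 1 belongs to its chain and how much to its bromo, since both differ together in its step to compound 4.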